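Swapping a Pyridylmethyl Arm for Isobutyl in a Weak Series

The compounds below may be only part of what the source reports. "The series", "measured", "known", "first", "only" and "open" are said of these compounds alone.

For the measured compounds named here, compound 1 `Cc1cc(Nc2nn(Cc3ccncc3)c(=O)c3ccccc23)n[nH]1` is the only member of this small set with a numerical result: in a functional assay on HCT-116 cells (Homo sapiens) for cytotoxicity, read by CellTiter-Glo, with a stated time of 5 days (a lower number here means a stronger inhibitor, a higher number a weaker inhibitor), compound 1 gives 20200 nM. Compound 2 `CC(=O)Nc1ccc(Cn2nc(Nc3cc[nH]n3)c3ccccc3c2=O)cc1` reaches only a limit of the assay, since in this assay compound 2 gives > 30000 nM. Compound 3 `Cc1ccc(-n2nc(Nc3cc[nH]n3)c3ccccc3c2=O)cc1` has no number to show: in this assay compound 3 gives "not determined" (no result reported). Compound 1 therefore stands alone as a weak inhibitor, with one companion sitting at the limit of > 30000 nM in this assay, at which 1 of the 3 values shown sits, and one companion without a number at all.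

Compound 4 `Cc1cc(Nc2nn(CC(C)C)c(=O)c3ccccc23)n[nH]1` carries isopropyl in place of pyridin-4-yl on a saturated chain carbon bound to an aromatic nitrogen. Going by the values given here, no measured pair in this set differs in a single place, so no step size can be drawn from the numbers themselves; all that the results show is that this series sits in a weak region. The step of a 1.2-fold higher number from compound 1 to compound 4 (0.09 log units; within the scatter) is expected to lie within the usual scatter, or a little toward weaker inhibition. In this assay compound 4 is estimated at 25000 nM, with a range from 8000 nM to 60000 nM.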

Compound 4, half-maximal inhibitory concentration: 1100 nM
Compound 4: middle estimate off by 23-fold (1.36 log units), on the high side; the measured number lies below the stated range.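

In this assay, for the compounds shown here, the change on the saturated chain carbon bound to an aromatic nitrogen provides the first comparison in one place, and it gives an 18-fold lower number from compound 1 to compound 4 (1.26 log units; beyond the scatter). This position therefore responds strongly: going from (pyridin-4-yl)methyl to isobutyl, which removes the six-membered aromatic ring and brings in no ring, takes compound 4 out of the weak region where compound 1 stands. Compound 2 remains at a limit of the assay, so it supplies no step: the limit of > 30000 nM in this assay, at which 1 of the 4 values shown sits.

The compounds shown leave open whether the stronger result follows from the isobutyl group itself or from the loss of pyridin-4-yl. They also leave open how a longer chain, a cyclopropylmethyl group or a chain bearing an amine would read at this position.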